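This account rests on a few compounds, and the source may have more. Where it says the series, first, only, none or still open, it means among the compounds named here.

Measured in a functional assay on MDA-MB-231 cells (Homo sapiens) for inhibition, read by CellTiter-Glo, with a stated time of 72 h; a higher number here means that more compound is tolerated, a lower number that less compound is tolerated:
- compound 1 `CC1=C(CC(=O)N2CCN(c3ccncc3)CC2)c2cc(F)ccc2/C1=C\c1ccc([S+](C)[O-])cc1`: 22700 nM
- compound 2 `CC1=C(CC(=O)NCCN2CCCC2)c2cc(F)ccc2/C1=C\c1nc2ccccc2s1`: 3560 nM
- compound 3 `CC1=C(CC(=O)N2CCN(CCCN(C)C)CC2)c2cc(F)ccc2/C1=C\c1nc2ccccc2s1`: 2900 nM

Compound 3, at 2900 nM, lies within the scatter of compound 2 and well under compound 1, which gives 22700 nM. Compound 4 `CC1=C(CC(=O)N2CCN(c3ccncc3)CC2)c2cc(F)ccc2/C1=C\c1nc2ccccc2s1` keeps the shared core of compound 3 and alters one group: pyridin-4-yl in place of 3-(dimethylamino)propyl on an amine nitrogen in a ring. In words, pyridin-4-yl stands in place of 3-(dimethylamino)propyl on an amine nitrogen in a ring.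

Among the compounds with values here, only one measured step bears directly on a change in this part of the molecule. That is a 1.2-fold lower number from compound 2 to compound 3 (0.09 log units; within the scatter), where one amide group replaced another on the same core and the number barely moved. The 4-(pyridin-4-yl)piperazin-1-yl group of compound 4 is already present in compound 1, and compound 1 gives 22700 nM. Compound 1 differs from compound 4 elsewhere as well. Within the data shown here, no measured pair isolates the contribution of this group, so compound 1 widens the upper side of the expectation without fixing the centre.

A small upward move is therefore expected, and the estimated step is a 1.6-fold higher number from compound 3 to compound 4 (0.19 log units; within the scatter). For compound 4 the estimated value is 4500 nM, with an expected range from 1500 nM to 14000 nM.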

Compound 4, half-maximal cytotoxic concentration: 7710 nM
The estimate for compound 4 lay 1.7-fold (0.23 log units) below the measured number, and the stated range covers the measured number.
By their numbers in this assay, from the lowest: compounds 3 and 2 (each within the scatter of the next); then compound 4; then compound 1.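

In this assay, pyridin-4-yl in place of 3-(dimethylamino)propyl on an amine nitrogen in a ring gives a 2.7-fold higher number from compound 3 to compound 4 (0.42 log units; beyond the scatter), so this position responds modestly to exchanging an open chain for an aromatic ring with the same heavy-atom tally. The wider amide comparison agrees: where the earlier exchange of amide groups stayed within the scatter, 4-(pyridin-4-yl)piperazin-1-yl in place of (2-(pyrrolidin-1-yl)ethyl)amino gives a 2.2-fold higher number from compound 2 to compound 4 (0.34 log units; beyond the scatter), which sets this amide apart from the other two on this core. With 4-(pyridin-4-yl)piperazin-1-yl held constant, changing the group on the double-bonded chain carbon gives a 2.9-fold lower number from compound 1 to compound 4 (0.47 log units; beyond the scatter), so this amide group alone does not carry the full height of the highest number in the set.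

Nothing available here gives a reason for the upward step at the ring nitrogen. As far as these compounds go, it also remains open whether a phenyl or a cyclohexyl group on that nitrogen would sit with compound 4 or with compound 3, a comparison that would separate the contributions of the pyridine nitrogen, the aromatic ring and the loss of the 3-(dimethylamino)propyl chain.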